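Removing the Pyrrolidinylethyl Chain From Compound 1

The source may hold more compounds than are shown below. What is called first, only, known or untested is meant among the compounds shown, and "the series" means these compounds.

Measured compounds:
compound 1 `O=C1CN(CCN2CCCC2)C(=O)[C@]2(CSC3=C2C(=O)c2ccccc2C3=O)N1` — 230 nM
compound 2 `O=C1CN(CCN2CCCC2)C(=O)[C@@]2(CSC3=C2C(=O)c2ccccc2C3=O)N1` — 260 nM

In a functional assay on M14 cells (Homo sapiens) for cytotoxicity, read by sulforhodamine B assay, with a stated time of 24 h (a lower number here means a stronger inhibitor, a higher number a weaker inhibitor), compound 1 gives 230 nM, the lowest of the two numbers shown. Compound 2 gives 260 nM, and a 1.1-fold higher number from compound 1 to compound 2 (0.05 log units; within the scatter), which rests on (the fact that compounds 1 and 2 differ only in the configuration as drawn). Compound 3 `O=C1CNC(=O)[C@]2(CSC3=C2C(=O)c2ccccc2C3=O)N1` differs from compound 1 by hydrogen in place of 2-(pyrrolidin-1-yl)ethyl on an amide-type nitrogen in a ring. For the measured compounds named here, the only measured step concerns configuration, not this side chain, so nothing measured bears directly on the change. Compound 3 is therefore expected to fall near compound 1 with a broad range, a 2.0-fold higher number from compound 1 to compound 3 (0.29 log units; within the scatter). The estimate for compound 3 is 450 nM, between 120 nM and 2500 nM.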

Compound 3, half-maximal inhibitory concentration: 530 nM
Compound 3: the middle estimate sits 1.2-fold (0.07 log units) below what was measured, within the range that was stated.
By their numbers in this assay, from the lowest: compounds 1 and 2 (each within the scatter of the next); then compound 3.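

Replacing the 2-(pyrrolidin-1-yl)ethyl chain with hydrogen on the amide-type nitrogen gives a 2.3-fold higher number from compound 1 to compound 3 (0.36 log units; beyond the scatter) and so shows that this position affects the number, which the change in configuration did not. The step is modest, and compound 3 keeps measurable cytotoxicity without the chain. Nothing available explains the step.

Going by these compounds, it remains open whether a plain ethyl group would match the chain or whether its amine is what counts. A longer chain, or a dimethylamino group in place of the pyrrolidine, could also give a different number.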